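The compounds below may be only part of what the source reports. "The series", "measured", "known", "first", "only" and "open" are said of these compounds alone.

For the measured compounds named here, in an ADME assay on HEL cells (Homo sapiens) for cytotoxicity (on this read-out higher numbers stand for lower toxicity in this test and lower numbers for higher toxicity in this test), compound 2 `O=C(COc1cccc2ccccc12)N/N=C/c1ccccc1Br` stands highest of the three numbers measured so far, at 100 ug/mL. Compound 3 `C/C(=N\NC(=O)COc1cccc2ccccc12)c1ccccc1` is nearest to it, giving 20 ug/mL, and compound 1 `C/C(=N\NC(=O)COc1cccc2ccccc12)c1ccc(C#N)cc1Br` is furthest, giving 12.7 ug/mL; both of these gaps lie beyond the scatter. Compound 4 `CSc1ccc(/C=N/NC(=O)COc2cccc3ccccc23)cc1` has not yet been measured. It differs from compound 2 in one place: 4-(methylsulfanyl)phenyl in place of 2-bromophenyl on a carbon with a double bond to nitrogen.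

Going by the values given here, only one measured step in this assay bears on a change of the aryl group on the carbon with a double bond to nitrogen. Among the compounds with values here, that step, a 1.6-fold higher number from compound 1 to compound 3 (0.20 log units; within the scatter), stayed within the scatter, so the one exchange of this kind that the data show did not move the number much. Compound 2 and compound 3 differ in two places, so their values only show that the numbers can spread beyond the scatter across such changes. On this thin basis, a step from compound 2 to compound 4 of no clear size beyond the scatter is expected, though a somewhat lower number is thought slightly more likely, and the estimated step is a 2.0-fold lower number from compound 2 to compound 4 (0.30 log units; within the scatter). Compound 4 is therefore expected to give about 50 ug/mL in this assay, between 15 ug/mL and 120 ug/mL.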

Compound 4, half-maximal cytotoxic concentration: > 100 ug/mL
Compound 4: a limit, no number (the forecaster's own chance of this, stated with the estimate: 10%); middle value at least 2.0-fold (0.30 log units) from the limit.
By their numbers in this assay, from the lowest: compounds 1 and 3 (each within the scatter of the next); then compound 2.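

In this assay compound 4 gives > 100 ug/mL, which is a limit of the assay and not a number. On a carbon with a double bond to nitrogen, the exchange of 2-bromophenyl for 4-(methylsulfanyl)phenyl gives a number no lower from compound 2 to compound 4 (the limit leaves the size open), so the bromine-bearing group is not needed to keep the number at the top of those shown, and this place accepts a larger group that carries a sulfur atom and a hydrogen-bond acceptor without a drop in the number. How much further the number might go cannot be told, and the comparison ends at the top of what this test reports: the limit of > 100 ug/mL in this assay, at which 1 of the 4 values shown sits.

The compounds shown leave open whether the sulfur atom of the 4-(methylsulfanyl)phenyl group plays any part, which 4-methoxyphenyl at the same place could test against compound 4 in a measurement that stays under the limit. They also leave open whether an aryl group carrying an amine or a carboxylic acid at this place would keep the number as high or bring it down.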